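Swapping the chlorophenoxy arm for an imidazolyl group

The source may report more compounds than this note shows. Statements on the series, on what has been measured and on what is new or still open speak of the compounds shown alone.

Measured compounds:
compound 1 `CCCCCc1cc(C)c(C(=O)N=C(N)N)cc1S(C)(=O)=O` 27 nM
compound 2 `Cc1cc(O)c(S(C)(=O)=O)cc1C(=O)N=C(N)N` 220 nM
compound 3 `Cc1cc(Oc2ccc(Cl)cc2)c(S(C)(=O)=O)cc1C(=O)N=C(N)N` 13 nM

All three were tested in a functional assay for inhibition of sodium/hydrogen exchanger (Oryctolagus cuniculus); a lower number here means a stronger inhibitor, a higher number a weaker inhibitor. Compound 3 gives the lowest number of the three; the two steps into it are a 2.1-fold lower number from compound 1 to compound 3 (0.32 log units; beyond the scatter) and a 17-fold lower number from compound 2 to compound 3 (1.23 log units; beyond the scatter). Compound 4 `Cc1cc(-n2ccnc2)c(S(C)(=O)=O)cc1C(=O)N=C(N)N` differs from compound 3 by 1H-imidazol-1-yl in place of 4-chlorophenoxy on an aromatic carbon. Within the data shown here, the steps that bear on this change are those leading into compound 3: a 2.1-fold lower number from compound 1 to compound 3 (0.32 log units; beyond the scatter) and a 17-fold lower number from compound 2 to compound 3 (1.23 log units; beyond the scatter), showing that what sits at this position matters, with a larger ring group giving the lowest numbers. Compound 4 keeps a ring there, so a small weakening is expected, a 3.5-fold higher number from compound 3 to compound 4 (0.54 log units; beyond the scatter). Compound 4 is estimated at 45 nM, between 15 nM and 150 nM.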

Compound 4, half-maximal inhibitory concentration: 23 nM
Compound 4: middle estimate off by 2.0-fold (0.29 log units), on the high side, and the stated range covers the measured number.
By their numbers in this assay, from the lowest: compounds 3, 4 and 1 (each within the scatter of the next, the first and the last beyond it); then compound 2.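

In this assay, the smaller 1H-imidazol-1-yl ring, with its two nitrogens, does about as well at this position as 4-chlorophenoxy, with a 1.8-fold higher number from compound 3 to compound 4 (0.25 log units; within the scatter). It also matches the pentyl chain, with a 1.2-fold lower number from compound 1 to compound 4 (0.07 log units; within the scatter), while hydroxy stays clearly apart, with a 9.6-fold lower number from compound 2 to compound 4 (0.98 log units; beyond the scatter). A low number here therefore needs neither the chlorine-bearing ring nor the oxygen link, and nothing measured here offers a reason for this. Still open, from the compounds shown here alone, is how an amine or a carboxylic acid would behave at this position, and whether a plain phenyl ring would match these groups.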